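The source may hold more compounds than are shown below. What is called first, only, known or untested is meant among the compounds shown, and "the series" means these compounds.

Compound 1 `O=C(O)CCC/C=C1\CC2C[C@@H](O)[C@H](/C=C/[C@@H](O)C3COc4ccccc4O3)C2C1` is one of two prostaglandin-type acids measured in a functional assay on the whole organism (stomach) for inhibition, with Rattus norvegicus as the target; on this read-out higher numbers stand for an effect only at larger amounts of compound and lower numbers for an effect already at smaller amounts; in that read-out compound 1 gives 0.0045 mg/kg, which is the higher of the two numbers. Going by the values given here, compound 2 `COc1ccc2c(c1)OCC([C@H](O)/C=C/[C@@H]1C3C/C(=C/CCCC(=O)O)CC3C[C@H]1O)O2` gives 0.0021 mg/kg, and the only measured step, a 2.1-fold lower number from compound 1 to compound 2 (0.33 log units; beyond the scatter), comes from a methoxy in place of hydrogen on an aromatic carbon.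

Compound 3 `O=C(O)CCC/C=C1\CC2C[C@@H](O)[C@H](/C=C/[C@@H](O)C3Cc4ccccc4C3)C2C1` has not yet been measured. It differs from compound 1 in one place: 2,3-dihydro-1H-inden-2-yl in place of 2,3-dihydro-1,4-benzodioxin-2-yl on a saturated chain carbon bound to a double-bonded chain carbon and an oxygen on a saturated carbon. Among the compounds with values here, the 2,3-dihydro-1,4-benzodioxin-2-yl group that leaves carries two hydrogen-bond acceptors, and the 2,3-dihydro-1H-inden-2-yl group that enters carries none, so this change is not of the same kind as the methoxy step between compound 1 and compound 2, and no measured step bears on it directly. Without such guidance, only a cautious expectation can be given: the number for compound 3 in this assay is estimated to lie at 0.007 mg/kg, within a range from 0.0025 mg/kg to 0.02 mg/kg, which means an expected step of a 1.6-fold higher number from compound 1 to compound 3 (0.19 log units; within the scatter), with a slightly higher number thought somewhat more likely than a lower one.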

Compound 3, dose for half-maximal effect: 0.0562 mg/kg
Compound 3: the middle estimate sits 8.0-fold (0.90 log units) below what was measured; measured number outside the range, above it.
By their numbers in this assay, from the lowest: compound 2; then compound 1; then compound 3.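

At this position, on a saturated chain carbon bound to a double-bonded chain carbon and an oxygen on a saturated carbon, the choice of ring group counts for much more than the aromatic methoxy step had shown. In this assay, the modest 2.1-fold lower number from compound 1 to compound 2 (0.33 log units; beyond the scatter) is far exceeded by the large 12-fold higher number from compound 1 to compound 3 (1.10 log units; beyond the scatter) when 2,3-dihydro-1H-inden-2-yl, with no hydrogen-bond acceptors, takes the place of 2,3-dihydro-1,4-benzodioxin-2-yl, with two. That one change also swaps a six-membered non-aromatic ring with two hetero atoms for a five-membered one of carbon only, and no measurement given here explains the size of the step.

The compounds shown therefore do not separate the loss of the ring oxygens from the change in ring size, a question that 1,2,3,4-tetrahydronaphthalen-2-yl, a six-membered counterpart of carbon only, or 2,3-dihydrobenzofuran-2-yl, with a single ring oxygen, would address. As far as these compounds go, it also remains open whether a methoxy group on the aromatic ring of the 2,3-dihydro-1H-inden-2-yl group would give a step like the one seen with the 2,3-dihydro-1,4-benzodioxin-2-yl group.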